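The source may report more compounds than this note shows. Statements on the series, on what has been measured and on what is new or still open speak of the compounds shown alone.

Of the compounds shown here, three of one series have been measured in an assay on cells for antagonist activity at transient receptor potential cation channel subfamily V member 1 (Homo sapiens), read by FLIPR and calcium flux, with a stated time of 6 min; on this read-out lower numbers stand for stronger inhibition and higher numbers for weaker inhibition. Compound 1 `CCCCCSc1nc(C(C)(C)C)ccc1CNC(=O)C(C)c1ccc(NS(C)(=O)=O)c(F)c1` gives 3.1 nM, compound 2 `CCCCCCSc1nc(C(C)(C)C)ccc1CNC(=O)C(C)c1ccc(NS(C)(=O)=O)c(F)c1` gives 1.5 nM, and compound 3 `CCCOc1cc(C(C)(C)C)ccc1CNC(=O)C(C)c1ccc(NS(C)(=O)=O)c(F)c1` gives 4.4 nM, the highest of the three numbers, although its gap to compound 1 lies within the scatter. Compound 4 `CC(C)CCOc1cc(C(C)(C)C)ccc1CNC(=O)C(C)c1ccc(NS(C)(=O)=O)c(F)c1` differs from compound 3 by isopropyl in place of methyl on a saturated chain carbon, two bonds along the chain from an oxygen on an aromatic ring. Among the measured compounds shown here, the only measured step, a 2.1-fold lower number from compound 1 to compound 2 (0.32 log units; beyond the scatter), concerns a chain on a sulfur rather than on an oxygen, so it bears only loosely on this change; it does suggest that adding carbon to such a chain lowers the number modestly. A step of similar size is therefore expected, so that a 1.8-fold lower number from compound 3 to compound 4 (0.25 log units; within the scatter). Compound 4 is estimated at 2.5 nM, within a range from 1 nM to 6 nM.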

Compound 4, inhibition constant: 0.6 nM
Compound 4: the middle estimate sits 4.2-fold (0.62 log units) above what was measured; the measured number lies below the stated range.
By their numbers in this assay, from the lowest: compound 4; then compound 2; then compounds 1 and 3 (each within the scatter of the next).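

In this assay the change from propoxy to isopentyloxy gives a 7.3-fold lower number from compound 3 to compound 4 (0.87 log units; beyond the scatter) on the oxygen chain. That step is larger than a 2.1-fold lower number from compound 1 to compound 2 (0.32 log units; beyond the scatter) on the sulfur chain, so adding carbon at this place can lower the number well beyond a modest change. Nothing measured here explains the size of this step.

As far as these compounds go, whether the branch or the added length matters more remains open, and a straight pentyloxy chain would separate the two. From the compounds shown here alone, how an amine at the end of the chain would read also remains open.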